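The compounds below may be only part of what the source reports. "The series", "measured", "known", "first", "only" and "open" are said of these compounds alone.

The measured compounds are:

compound 1, `N#Cc1ccc(S(=O)(=O)N2C/C(=C\c3cccnc3)C(=O)/C(=C/c3ccccc3F)C2)cc1`, which in a functional assay on HepG2 cells (Homo sapiens) for cytotoxicity, read by MTT assay, with a stated time of 24 h (a higher number here means a weaker inhibitor, a lower number a stronger inhibitor), gives 6600 nM;
compound 2, `CC(=O)Nc1ccc(S(=O)(=O)N2C/C(=C\c3cccnc3)C(=O)/C(=C/c3ccccc3F)C2)cc1`, which in this assay gives 4560 nM;
compound 3, `N#Cc1ccc(S(=O)(=O)N2C/C(=C\c3cccnc3)C(=O)/C(=C/c3ccccc3C(F)(F)F)C2)cc1`, which in this assay gives 5060 nM.

All three share one core, and the numbers of all three lie within the usual scatter of one another, so none of them can be called the stronger or the weaker inhibitor. Compound 4, `CC(=O)Nc1ccc(S(=O)(=O)N2C/C(=C\c3cccnc3)C(=O)/C(=C/c3ccccc3C(F)(F)F)C2)cc1`, has not yet been measured in this assay. It stands to compound 3 as compound 2 stands to compound 1. The new change is acetamido in place of cyano on an aromatic carbon. The measured one reads (acetamido in place of cyano on an aromatic carbon). The two places are described in the same words, so this is the same change, and in this assay it brought a 1.4-fold lower number from compound 1 to compound 2 (0.16 log units; within the scatter). The two pairs sit on cores that differ in one spot: trifluoromethyl in place of fluoro on an aromatic carbon, a change that brought a 1.3-fold lower number from compound 1 to compound 3 (0.12 log units; within the scatter).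

Among the measured compounds shown here, for compound 4 the expected step is a 1.4-fold lower number from compound 3 to compound 4 (0.15 log units; within the scatter), because a 1.4-fold lower number from compound 1 to compound 2 (0.16 log units; within the scatter) is the only measured instance of this change and it stayed within the scatter. Compound 4 is therefore estimated at 3600 nM, with a likely range from 1800 nM to 7500 nM.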

Compound 4, half-maximal inhibitory concentration: 4330 nM
Estimate against measurement, compound 4: 1.2-fold (0.08 log units) below; the measured number falls inside the stated range.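

In this assay, acetamido in place of cyano on the core carrying trifluoromethyl gave a 1.2-fold lower number from compound 3 to compound 4 (0.07 log units; within the scatter), which agrees with the same change on the core carrying fluoro: the same change on two cores in this assay, a 1.4-fold lower number (0.16 log units; within the scatter) from compound 1 to compound 2 and a 1.2-fold lower number (0.07 log units; within the scatter) from compound 3 to compound 4, 1.2-fold (0.09 log units) apart, within the scatter of two such steps

Trifluoromethyl in place of fluoro, now on the core carrying acetamido, gave a 1.1-fold lower number from compound 2 to compound 4 (0.02 log units; within the scatter), and this agrees with the same change on the core carrying cyano: the same change on two cores in this assay, a 1.3-fold lower number (0.12 log units; within the scatter) from compound 1 to compound 3 and a 1.1-fold lower number (0.02 log units; within the scatter) from compound 2 to compound 4, 1.2-fold (0.09 log units) apart, within the scatter of two such steps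

So each of these two changes read the same on both cores, yet every one of these steps lies within the scatter, which means the agreement is only between steps too small to tell from repeated measurement, and it does not show that a real effect on the number passes from one core to the other, nor does a single square of four compounds set a rule for the wider series.

The compounds shown leave open what other groups at this place on the aromatic ring would do, for example an amine, a carboxylic acid or a longer chain on the amide in place of the acetamido methyl. They also leave open whether a change large enough to stand clear of the scatter would carry over between cores in the same way.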